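This account rests on a few compounds, and the source may have more. Where it says the series, first, only, none or still open, it means among the compounds named here.

Measured so far:
compound 1 `COc1cccc(CNC(=O)c2nc(Br)c3cccnc3c2N[C@H]2CC[C@H](N)CC2)c1`, 6000 nM
compound 2 `C[C@@H](CO)Nc1nc(C(=O)NCc2ccc(F)cc2)c(O)c2ncccc12`, "not determined" (no result reported)
compound 3 `NCCNc1c(C(=O)NCc2ccc(F)cc2)nc(Br)c2cccnc12`, > 20000 nM

Among the measured compounds shown here, in a functional assay on HCT-116 cells (Homo sapiens) for cytotoxicity, read by MTT assay, with a stated time of 72 h (on this read-out lower numbers stand for stronger inhibition and higher numbers for weaker inhibition), compound 1 gives 6000 nM, the only plain number among the three compounds. Compound 2 has "not determined" (no result reported) in this assay. Compound 3 gives > 20000 nM, which is a limit of the assay and not a number: the limit of > 20000 nM in this assay, at which 1 of the 3 values shown sits. Compound 4 `N[C@H]1CC[C@H](Nc2c(C(=O)NC3CCCCC3)nc(Br)c3cccnc23)CC1` differs from compound 1 by cyclohexyl in place of 3-methoxybenzyl on an amide-type nitrogen. For the measured compounds named here, no step between two measured compounds is known, so the weight of this change cannot be read from the data. A step from compound 1 to compound 4 that stays within the usual scatter, or drifts somewhat toward weaker inhibition, is expected. Compound 4 is therefore estimated at 10000 nM, with a range from 3000 nM to 30000 nM, which means an expected step of a 1.7-fold higher number from compound 1 to compound 4 (0.22 log units; within the scatter).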

Compound 4, half-maximal inhibitory concentration: > 10000 nM
Compound 4: only a limit was reported; the forecaster's own chance of this, stated with the estimate: 30%; the middle value lies on the limit itself.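

In this assay, putting cyclohexyl in place of 3-methoxybenzyl on the amide-type nitrogen gives an at least 1.6-fold higher number from compound 1 to compound 4 (0.22 log units; that floor lies within the scatter). Among the compounds shown here, this is the only step here between two measured compounds, and it shows that this swap at least does not lower the number. The result for compound 4 is a limit of the assay and not a number: the limit of > 10000 nM in this assay, at which 1 of the 4 values shown sits.

From the compounds shown here alone, the true size of the step remains unknown, so the importance of the aromatic ring at this position stays unsettled. Also open, going by these compounds, is how a small methyl group or a benzyl group carrying a carboxylic acid would fare on this nitrogen.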